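Working notes: from compound 2 to compound 3

This account rests on a few compounds, and the source may have more. Where it says the series, first, only, none or still open, it means among the compounds named here.

Compound 1 `COc1ncc(-c2ccc3nc(NC(=O)NCC(=O)N4CCCCC4)nn3c2)cc1NS(=O)(=O)c1ccc(F)cc1`: 130 nM
Compound 2 `COc1ncc(-c2ccc3nc(NC(=O)NCC(=O)N4CCOCC4)nn3c2)cc1NS(=O)(=O)c1ccc(F)cc1`: 490 nM

In a functional assay on HCT-116 cells (Homo sapiens) for cytotoxicity, read by MTT assay, with a stated time of 72 h (a lower number here means a stronger inhibitor, a higher number a weaker inhibitor), compound 2 stands higher of the two at 490 nM. Compound 3 `CNC(=O)Nc1nc2ccc(-c3cnc(OC)c(NS(=O)(=O)c4ccc(F)cc4)c3)cn2n1` follows from compound 2 by hydrogen in place of (morpholin-4-yl)carbonyl on a saturated chain carbon bound to an amide-type nitrogen. Among the compounds with values here, only one measured step bears on this, and only indirectly: a 3.8-fold higher number from compound 1 to compound 2 (0.58 log units; beyond the scatter). Within the data shown here, that step swaps the group on the carbonyl carbon, whereas here the whole (morpholin-4-yl)carbonyl leaves, and no measured compound lacks it. A modest change is therefore expected, leaning towards a lower number, with the direction uncertain. The estimated step is a 2.0-fold lower number from compound 2 to compound 3 (0.29 log units; within the scatter). For compound 3 the expected value is 250 nM, with an estimated range of 60 nM to 1000 nM.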

Compound 3, half-maximal inhibitory concentration: 180 nM
The estimate for compound 3 lay 1.4-fold (0.14 log units) above the measured number; the measured number falls inside the stated range.
By their numbers in this assay, from the lowest: compounds 1 and 3 (each within the scatter of the next); then compound 2.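

In this assay the loss of (morpholin-4-yl)carbonyl gives a 2.7-fold lower number from compound 2 to compound 3 (0.43 log units; beyond the scatter) and so this group is not required on the saturated chain carbon bound to an amide-type nitrogen. The loss of (piperidin-1-yl)carbonyl gives a 1.4-fold higher number from compound 1 to compound 3 (0.14 log units; within the scatter) and so, of these three, compound 2 alone stands apart. No evidence available here explains these differences. Still open, going by these compounds, is how a carboxylic acid, a primary amine or a longer chain on this carbon would read in this assay and whether any of them would differ from the plain methyl of compound 3.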